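Cyclohexyl, isobutyl, phenyl at the aromatic carbon

The compounds below may be only part of what the source reports. "The series", "measured", "known", "first", "only" and "open" are said of these compounds alone.

Going by the values given here, compound 2 `COc1cccc(CNCCCNc2ccnc3cc(CC(C)C)ccc23)c1O` gives 2920 nM in an ADME assay on HepG2 cells (Homo sapiens) for cytotoxicity, read by luminescence, CellTiter-Glo and ATP content, with a stated time of 72 h (on this read-out lower numbers stand for an effect already at smaller amounts and higher numbers for an effect only at larger amounts of compound), the higher of the two numbers so far; compound 1 `COc1cccc(CNCCCNc2ccnc3cc(C4CCCCC4)ccc23)c1O` gives 1080 nM. Compound 3 `COc1cccc(CNCCCNc2ccnc3cc(-c4ccccc4)ccc23)c1O` differs from compound 2 by phenyl in place of isobutyl on an aromatic carbon. Among the compounds with values here, only one measured step bears on this change, a 2.7-fold higher number from compound 1 to compound 2 (0.43 log units; beyond the scatter), and it concerns a different pair of groups. Because a 2.7-fold higher number from compound 1 to compound 2 (0.43 log units; beyond the scatter) went with the loss of a six-membered ring and phenyl brings one back, a modest move toward a lower number is expected for compound 3. The expected step is a 1.6-fold lower number from compound 2 to compound 3 (0.21 log units; within the scatter). Compound 3 is estimated at 1800 nM, range 700 nM to 5000 nM.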

Compound 3, half-maximal effective concentration: 3210 nM
The estimate for compound 3 lay 1.8-fold (0.25 log units) below the measured number; the range from low to high includes it.
By their numbers in this assay, from the lowest: compound 1; then compounds 2 and 3 (each within the scatter of the next).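

Phenyl and isobutyl on this aromatic carbon cannot be told apart in this assay, with a 1.1-fold higher number from compound 2 to compound 3 (0.04 log units; within the scatter) as the step. Against cyclohexyl the picture differs, with a 3.0-fold higher number from compound 1 to compound 3 (0.47 log units; beyond the scatter), so a six-membered ring at this place does not alone go with the lower number: compound 1 has the lower number, and compound 3 goes against any such link. Nothing available accounts for the gap between cyclohexyl and phenyl.

From the compounds shown here alone, whether a smaller ring such as cyclopentyl stays close to compound 1 remains open. So does whether an amine or a carboxylic acid at this carbon moves the number at all.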